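Aryl sulfone series at metabotropic glutamate receptor 5

The source may hold more compounds than are shown below. What is called first, only, known or untested is meant among the compounds shown, and "the series" means these compounds.

Measured compounds:
compound 1 `CC1CCN(c2c(S(=O)(=O)c3cc(F)cc(F)c3)cnc3c(F)cccc23)CC1` gives 9%
compound 2 `CC1CCN(c2c(S(=O)(=O)c3ccc(Cl)cc3)cnc3c(F)cccc23)CC1` gives 85%
compound 3 `CC1CCN(c2c(S(=O)(=O)c3ccc(Cl)cc3)cnc3ccc(Cl)cc23)CC1` gives 92%

All three were run in an assay on isolated protein for displacement of a labelled ligand from metabotropic glutamate receptor 5 (Homo sapiens), with a stated time of 60 min, tested at 1 uM; on this read-out higher numbers stand for more inhibition at the one concentration tested (going by the name of the read-out) and lower numbers for less inhibition. Compound 2 and compound 3 share the same aryl sulfone but carry different cores; the difference between the two cores is not broken down here, and their two numbers lie within the scatter of each other. Going by the values given here, the one counted step is 3,5-difluorophenyl in place of 4-chlorophenyl on a sulfonyl sulfur, which gave a number 76 percentage points lower from compound 2 to compound 1 (beyond the scatter). Compound 4 `CC1CCN(c2c(S(=O)(=O)c3cc(F)cc(F)c3)cnc3ccc(Cl)cc23)CC1` is not yet measured; it is related to compound 3 by 3,5-difluorophenyl in place of 4-chlorophenyl on a sulfonyl sulfur, the same change as that from compound 2 to compound 1. A step of similar size is expected, a number 74 percentage points lower from compound 3 to compound 4 (beyond the scatter), resting on compound 2 and compound 1 and a number 76 percentage points lower from compound 2 to compound 1 (beyond the scatter). On that basis compound 4 is estimated at 18%, with a range from 5% to 40%.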

Compound 4, a percentage reported as inhibition, at one concentration (the size of the read-out at that concentration, not a potency): 93%
Estimate against measurement, compound 4: 75 percentage points below; measured number above the stated range.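

In this assay, 3,5-difluorophenyl in place of 4-chlorophenyl on a sulfonyl sulfur gives a number 1 percentage points higher from compound 3 to compound 4 (within the scatter), so the large loss seen on the other core does not carry over: the same change on two cores in this assay, a number 76 percentage points lower (beyond the scatter) from compound 2 to compound 1 and a number 1 percentage points higher (within the scatter) from compound 3 to compound 4, 77 percentage points apart, beyond the scatter of two such steps. In these two pairs the result of the change depends on the core, but the pairs do not show which difference between the cores matters, and they give no rule for any further core. Each number is the size of the effect at one concentration, and how compound 3 and compound 4 compare at any other concentration is not shown.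

Open, as far as these compounds go, is how a nitrile or a methoxy group on the aryl ring of the sulfone would behave on either core. Also open, from the compounds shown here alone, is which of the two results a third core would follow.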